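The compounds below may be only part of what the source reports. "The series", "measured", "known", "first", "only" and "open" are said of these compounds alone.

In an ADME assay on HEK-293T cells (Homo sapiens) for cytotoxicity, read by CCK-8 assay, with a stated time of 48 h (a higher number here means a weaker inhibitor, a lower number a stronger inhibitor), compound 2 (`COc1ccc(NC(=O)NCCNS(=O)(=O)c2ccc(-c3ccccc3OCc3cccc(O)c3)s2)cc1`) reads > 20000 nM, which is a limit and not a number. Compound 1 (`Cc1cc(C)cc(NC(=O)NCCNS(=O)(=O)c2ccc(-c3ccccc3Oc3ccc([N+](=O)[O-])c([N+](=O)[O-])c3)s2)c1`), which carries a 3,4-dinitrophenyl on an oxygen on an aromatic ring, reads > 50000 nM, also a limit. Compound 3 (`COc1ccc(NC(=O)NCCNS(=O)(=O)c2ccc(-c3ccccc3Oc3ccc([N+](=O)[O-])c([N+](=O)[O-])c3)s2)cc1`) has 3,4-dinitrophenyl in place of 3-hydroxybenzyl on an oxygen on an aromatic ring of compound 2: 3,4-dinitrophenyl in place of 3-hydroxybenzyl on an oxygen on an aromatic ring. No change beyond the scatter is expected in this assay, and the estimated step is a step that the limit leaves unreadable from compound 2 to compound 3. For compound 3 the expected value is 35000 nM, with an estimated range of 15000 nM to 80000 nM.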

Compound 3, half-maximal inhibitory concentration: 18500 nM
Compound 3: middle estimate off by 1.9-fold (0.28 log units), on the high side; the range from low to high includes it.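

In this assay, among the compounds shown here, compound 3 gives the first reading here that is a number and not a limit. As far as these compounds go, on an oxygen on an aromatic ring, 3,4-dinitrophenyl in place of 3-hydroxybenzyl gives an at least 1.0-fold lower number from compound 2 to compound 3 (0.03 log units; that floor lies within the scatter), so this floor does not show whether that change matters; it rests on a limit: the limit of > 20000 nM in this assay, at which 1 of the 3 values shown sits. On an amide-type nitrogen, 4-methoxyphenyl in place of 3,5-dimethylphenyl gives an at least 2.7-fold lower number from compound 1 to compound 3 (0.43 log units; beyond the scatter), so that place does move the reading, by a size also resting on a limit: the limit of > 50000 nM in this assay, at which 1 of the 3 values shown sits. How an amine or a carboxylic acid on that oxygen would read stays open, as does the true size of both steps.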